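The compounds below may be only part of what the source reports. "The series", "measured", "known", "first", "only" and "open" are said of these compounds alone.

Compound 1, `COc1ccc2c(-c3cc(C(F)(F)F)c(C#N)c(-c4cn(S(=O)(=O)c5ccc(C)cc5)c5cc(OC)ccc45)n3)cn(S(=O)(=O)c3ccc(C)cc3)c2c1`: 21.2%
Compound 2, `COc1ccc2c(c1)c(-c1cc(C(F)(F)F)cc(-c3cn(S(=O)(=O)c4ccc(C)cc4)c4ccc(OC)cc34)n1)cn2S(=O)(=O)c1ccc(C)cc1`: 41.7%
Compound 3, `Cc1ccc(S(=O)(=O)n2cc(-c3cc(C(F)(F)F)cc(-c4cn(S(=O)(=O)c5ccc(C)cc5)c5cc(Br)ccc45)n3)c3ccc(Br)cc32)cc1`: 49.2%

All three were tested in a functional assay on A549 cells (Homo sapiens) for inhibition, tested at 100 uM; a lower number here means a weaker effect, a higher number a stronger effect of the compound at the concentration tested. Among them compound 3 has the highest number; compound 2 lies within the usual scatter of it, so those two cannot be ranked, while compound 1 lies well below, beyond the scatter. The untested compound 4, `Cc1ccc(S(=O)(=O)n2cc(-c3cc(C(F)(F)F)c(C#N)c(-c4cn(S(=O)(=O)c5ccc(C)cc5)c5cc(Br)ccc45)n3)c3ccc(Br)cc32)cc1`, differs from compound 3 in a single place: cyano in place of hydrogen on an aromatic carbon. Among the measured compounds shown here, no pair of measured compounds differs by exactly this change, so the size of the step is uncertain. Still, compound 1 carries a cyano group where compound 2 carries none, and compound 1 gives the lower number of the two. A drop is therefore expected for the step of a number 19.2 percentage points lower from compound 3 to compound 4 (beyond the scatter), likely beyond the scatter. Compound 4 is estimated at 30%, within 15% to 45%.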

Compound 4, a percentage reported as inhibition, at one concentration (the size of the read-out at that concentration, not a potency): 48.1%
For compound 4 the middle estimate is 18.1 percentage points below the measured one, and the stated range ends below it.
By their numbers in this assay, from the lowest: compound 1; then compounds 2, 4 and 3 (each within the scatter of the next).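

In this assay, cyano in place of hydrogen on this aromatic carbon, ortho to a trifluoromethyl group and two atoms from the ring nitrogen, gives a number 1.1 percentage points lower from compound 3 to compound 4 (within the scatter). On this core, then, the position carries cyano with a read-out that cannot be told apart from that of the parent with hydrogen. Nothing available explains this result.

On these data alone, whether an amine or a carboxylic acid on the same carbon would also leave the read-out there stays open. Among the compounds shown here, whether cyano behaves alike on other cores, with only this one pair to read, stays open too.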